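Replacing one side group on the shared core

This account rests on a few compounds, and the source may have more. Where it says the series, first, only, none or still open, it means among the compounds named here.

- compound 1 `COC(c1cc(Cl)c2c(c1Cl)C(=O)N(Cc1c(C)cc(C)[nH]c1=O)CC2)C1CCOC1` gives 175 nM; 406 nM; 50 nM; 25 nM (4 entries) over four entries
- compound 2 `Cc1cc(C)c(CN2CCc3c(Cl)cc([C@@H](CO)[C@@H]4CCCO4)c(Cl)c3C2=O)c(=O)[nH]1` gives 1220 nM as its only number

Among the measured compounds shown here, in a functional assay on KARPAS-422 cells (Homo sapiens) for antiproliferative activity, read by resazurin assay, with a stated time of 72 h (on this read-out higher numbers stand for weaker inhibition and lower numbers for stronger inhibition), compound 2 stands at 1220 nM as its only number, and one further entry for compound 2 gives no single number. In this assay compound 1 gives 175 nM; 406 nM; 50 nM; 25 nM (4 entries) and these entries spread widely among themselves (the several entries of compound 1 in this assay, 175 nM; 406 nM; 50 nM; 25 nM (4 entries)), yet each reads lower than the number for compound 2.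

Compound 3 `Cc1cc(C)c(CN2CCc3c(Cl)cc(-c4c(C)noc4C)c(Cl)c3C2=O)c(=O)[nH]1` differs from compound 2 at one place (a group of 7 heavy atoms (5 carbon, 1 nitrogen, 1 oxygen; one five-membered aromatic ring with 2 hetero atoms) in place of a group of 8 heavy atoms (6 carbon, 2 oxygen; one five-membered non-aromatic ring with 1 hetero atom), on an aromatic carbon). There, 3,5-dimethyl-1,2-oxazol-4-yl enters on an aromatic carbon, ortho to a chloro group, and the five-membered non-aromatic ring leaves with its side chain.

For the measured compounds named here, no measured pair isolates this change, so the expectation is loose. Going by the values given here, it rests on compound 1 at 175 nM; 406 nM; 50 nM; 25 nM (4 entries) as the only other reading for a different group at this place. A moderate move toward stronger inhibition is expected, and the estimated change is a 3.1-fold lower number from compound 2 to compound 3 (0.48 log units; beyond the scatter) in this assay for this replacement. For compound 3 the estimated value is 400 nM within an expected range from 100 nM to 1600 nM in the coming measurement.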

Compound 3, half-maximal inhibitory concentration: 23 nM
The estimate for compound 3 lay 17-fold (1.24 log units) above the measured number; the whole stated range lies above it.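

In this assay, among the compounds shown here, 3,5-dimethyl-1,2-oxazol-4-yl on this aromatic carbon, in place of the five-membered non-aromatic ring with its side chain, gives a 53-fold lower number from compound 2 to compound 3 (1.72 log units; beyond the scatter), the only step printed at this position. The position is therefore far from indifferent to the group it carries, even though the heavy-atom count shifts only from 8 to 7; the entering group has 0 hydrogen-bond donors and no defined stereocentre, while the leaving group has 1 donor and 2 defined stereocentres. Compound 3 at 23 nM falls at the low end of what compound 1 shows in this assay, and no order between the two can be drawn from entries that spread this widely: the several entries of compound 1 in this assay, 175 nM; 406 nM; 50 nM; 25 nM (4 entries)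

The compounds shown leave open which difference carries the step: the aromatic ring, the loss of the hydrogen-bond donor or the loss of the two stereocentres. Also open, on these data alone, is how an amine, a carboxylic acid, a longer chain or a phenyl ring on this aromatic carbon would read in this assay.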